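Shortening the Hydrazide Chain of a Biphenyl Inhibitor

This account rests on a few compounds, and the source may have more. Where it says the series, first, only, none or still open, it means among the compounds named here.

Compound 1 `CCCCCNNC(=O)c1ccc(-c2ccc(CNC(C)=O)cc2)cc1` gives 350 nM in an assay on isolated protein for inhibition of histone deacetylase 8 (Homo sapiens), read by fluorescence, with a stated time of 5 min; on this read-out lower numbers stand for stronger inhibition and higher numbers for weaker inhibition.
Compound 2 `CCCNNC(=O)c1cnc(N2CCN(Cc3c[nH]c4ccccc34)CC2)nc1` gives 8.2 nM in this assay.

Of the two measured compounds, compound 1 stands with the higher number in this assay, and compound 2, built on a different core, gives the lower number; the gap between them lies beyond the scatter of repeat measurements. The cores differ. The two values say nothing about the chain alone.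

Compound 3 `CCCNNC(=O)c1ccc(-c2ccc(CNC(C)=O)cc2)cc1` keeps the core of compound 1 and changes only the chain: hydrogen in place of ethyl on a saturated chain carbon, three bonds along the chain from an amine nitrogen. Within the data shown here, no measured pair shows this change on its own. Without such a pair, only a modest step is expected, of about a 1.4-fold lower number from compound 1 to compound 3 (0.15 log units; within the scatter), leaning slightly toward a lower number but possibly within the scatter. Compound 3 is therefore expected to give about 250 nM in this assay, with a range from 70 nM to 900 nM.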

Compound 3, half-maximal inhibitory concentration: 700 nM
Compound 3: the middle estimate sits 2.8-fold (0.45 log units) below what was measured; low and high end bracket the measured number.
By their numbers in this assay, from the lowest: compound 2; then compounds 1 and 3 (each within the scatter of the next).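

Among these compounds, this is the first pair in which only the chain differs, so the chain can now be judged on its own: in this assay, replacing pentyl with propyl on the shared core gives a 2.0-fold higher number from compound 1 to compound 3 (0.30 log units; within the scatter) and leaves the two compounds indistinguishable. On this core, then, the ethyl at this saturated chain carbon can give way to hydrogen without a change that stands clear of the scatter. No further measurement offers an explanation for this result.

Going by these compounds, whether a butyl chain, a longer chain such as hexyl, or an amine at the chain end would keep the number in this range remains open. So does whether the same change would have as small an effect on the core of compound 2, which carries a propyl chain.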